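A Smaller Saturated Ring and Cell Growth Inhibition

A few compounds are considered here, and "the series" means these few. Any claim that something is new, unique, unknown or untested is made for them only; others in the source may bear on it.

Compound 1 `Cc1cccc(/C(N)=N/NC(=S)N2CCCCC2)n1` and compound 2 `Cc1cccc(/C(N)=N/NC(=S)N2CCCC2)n1` share one core and differ in a single spot: pyrrolidin-1-yl in place of piperidin-1-yl on a thiocarbonyl carbon. In a functional assay on HeLa cells (Homo sapiens) for cytotoxicity, read by MTT assay, with a stated time of 72 h, tested at 30 uM (a higher number here means more inhibition of growth at the concentration tested, a lower number less inhibition of growth), compound 1 gives 83.5%, and compound 2 gives 74.5%; the step of a number 9 percentage points lower from compound 1 to compound 2 (within the scatter). Compound 3 `Cc1ccnc(/C(N)=N/NC(=S)N2CCCCC2)c1` is built from the same atoms as compound 1, joined differently; the difference between the two cores is not broken down here. In this assay compound 3 gives 69.1%, which sits within the scatter of compound 2 but beyond the scatter from compound 1. Compound 4 `Cc1ccnc(/C(N)=N/NC(=S)N2CCCC2)c1` differs from compound 3 by the same change: pyrrolidin-1-yl in place of piperidin-1-yl on a thiocarbonyl carbon. Because the step of a number 9 percentage points lower from compound 1 to compound 2 (within the scatter) stayed within the scatter, a similar small step is expected here, a number 7.1 percentage points lower from compound 3 to compound 4 (within the scatter). Compound 4 is therefore expected to give 62% in this assay, most likely between 48% and 76%.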

Compound 4, percent growth inhibition at one concentration: 86.4%
Compound 4: the middle estimate sits 24.4 percentage points below what was measured; measured number above the stated range.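

In this assay, putting pyrrolidin-1-yl in place of piperidin-1-yl on a thiocarbonyl carbon gives a number 17.3 percentage points higher from compound 3 to compound 4 (beyond the scatter). Set beside the earlier step, the same change does not carry over unchanged from one core to the other: the same change on two cores in this assay, a number 9 percentage points lower (within the scatter) from compound 1 to compound 2 and a number 17.3 percentage points higher (beyond the scatter) from compound 3 to compound 4, 26.3 percentage points apart, beyond the scatter of two such steps This shows that the outcome of the change on the core of compound 1 is a poor guide to its outcome on the core of compound 3, but it does not show why the cores differ, and two pairs set no rule for any further core.

The compounds shown leave open how other groups on the thiocarbonyl carbon, such as morpholin-4-yl or an open-chain dimethylamino group, would behave on these two cores. On these data alone, whether such groups would also differ between the cores remains unknown.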